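Swapping one aromatic group for another on compound 3

A few compounds are considered here, and "the series" means these few. Any claim that something is new, unique, unknown or untested is made for them only; others in the source may bear on it.

In an ADME assay (liver) for metabolic stability, with Liver microsome (Homo sapiens) as the target, using microsomes and NADPH, with a stated time of 30 min, tested at 1 uM (a higher number here means faster removal of the compound, a lower number slower removal), compound 1 `Nc1ccc(S(=O)(=O)N2CCN(c3ncc(C(O)(C(F)(F)F)C(F)(F)F)cc3Br)CC2)cn1` gives < 14 mL.min-1.g-1, which is a limit of the assay and not a number. Compound 2 `NC(=O)c1cccc(-c2cc(C(O)(C(F)(F)F)C(F)(F)F)cnc2N2CCN(S(=O)(=O)c3ccc(N)nc3)CC2)c1` gives 17 mL.min-1.g-1. Compound 3 `Nc1ccc(S(=O)(=O)N2CCN(c3ncc(C(O)(C(F)(F)F)C(F)(F)F)cc3-c3cnccc3F)CC2)cn1` stands level with it at 17 mL.min-1.g-1. Compound 4 `Nc1ccc(S(=O)(=O)N2CCN(c3ncc(C(O)(C(F)(F)F)C(F)(F)F)cc3-c3ccc4scnc4c3)CC2)cn1` carries 1,3-benzothiazol-5-yl in place of 4-fluoropyridin-3-yl on an aromatic carbon. Among the measured compounds shown here, the closest precedent, one aromatic group exchanged for another, shows no change at the digits printed from compound 2 to compound 3 (within the scatter). Replacing bromo with an aromatic group gave an at least 1.2-fold higher number from compound 1 to compound 2 (0.08 log units; that floor lies within the scatter) and an at least 1.2-fold higher number from compound 1 to compound 3 (0.08 log units; that floor lies within the scatter). These steps are all small, so only a small change is expected here. The expected step is a 1.3-fold higher number from compound 3 to compound 4 (0.11 log units; within the scatter), with no clear move beyond the scatter. The estimate for compound 4 is 22 mL.min-1.g-1, with an expected range from 14 mL.min-1.g-1 to 40 mL.min-1.g-1.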

Compound 4, intrinsic clearance in microsomes: 39 mL.min-1.g-1
For compound 4 the middle estimate is 1.8-fold (0.25 log units) below the measured one; measured number inside the range.
By their numbers in this assay, from the lowest: compounds 2 and 3 (each within the scatter of the next); then compound 4. At a limit, below all of these: compound 1.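

In this assay, among the compounds shown here, exchanging one aromatic group for another at this position can move the number beyond the scatter, which no earlier step showed: 1,3-benzothiazol-5-yl gives a 2.3-fold higher number from compound 3 to compound 4 (0.36 log units; beyond the scatter) and a 2.3-fold higher number from compound 2 to compound 4 (0.36 log units; beyond the scatter). Against bromo it gives an at least 2.7-fold higher number from compound 1 to compound 4 (0.44 log units; beyond the scatter). That step is only a floor, as compound 1 stands at a limit and not at a number: the limit of < 14 mL.min-1.g-1 in this assay, at which 1 of the 4 values shown sits.

The compounds shown leave open whether the higher number goes with the second ring or with the sulfur atom. A phenyl group or a 1,3-benzoxazol-5-yl group at this position would help separate the two.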